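Chain Extension at the Amide in a Thienopyrimidine Series

A few compounds are considered here, and "the series" means these few. Any claim that something is new, unique, unknown or untested is made for them only; others in the source may bear on it.

Measured compounds:
compound 1, `CC/C=C/C(=O)Nc1cccc(Oc2nc(Nc3cccc(OC)c3)nc3c2CSCC3)c1`, 27200 nM
compound 2, `CCC/C=C/C(=O)Nc1cccc(Oc2nc(Nc3cccc(OC)c3)nc3c2CSCC3)c1`, 33800 nM
compound 3, `C/C=C/C(=O)Nc1cccc(Oc2nc(Nc3ccc(OC)cc3)nc3c2CSCC3)c1`, > 50000 nM

In a functional assay on HeLa cells (Homo sapiens) for antiproliferative activity, read by MTT assay, with a stated time of 72 h (a higher number here means a weaker inhibitor, a lower number a stronger inhibitor), compound 1 gives 27200 nM and compound 2 gives 33800 nM. The change between them is methyl in place of hydrogen on a saturated chain carbon, two bonds along the chain from a double-bonded chain carbon and the step is a 1.2-fold higher number from compound 1 to compound 2 (0.09 log units; within the scatter). For compound 3 only a limit is reported in this assay, namely > 50000 nM, where (the limit of > 50000 nM in this assay, at which 1 of the 3 values shown sits). The difference between the core of compound 3 and the core of compound 1 is not broken down here.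

Compound 4, `CC/C=C/C(=O)Nc1cccc(Oc2nc(Nc3ccc(OC)cc3)nc3c2CSCC3)c1`, has not been measured. It differs from compound 3 by methyl in place of hydrogen on a saturated chain carbon bound to a double-bonded chain carbon. This is the same kind of change as from compound 1 to compound 2, though the place differs: there the methyl enters on a saturated chain carbon two bonds along the chain from a double-bonded chain carbon, here on a saturated chain carbon bound to a double-bonded chain carbon. Since the earlier step was a 1.2-fold higher number from compound 1 to compound 2 (0.09 log units; within the scatter), the expected step is a step that the limit leaves unreadable from compound 3 to compound 4, and compound 4 is estimated at 55000 nM in this assay, between 25000 nM and 120000 nM.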

Compound 4, half-maximal inhibitory concentration: 27200 nM
For compound 4 the middle estimate is 2.0-fold (0.31 log units) above the measured one; the range from low to high includes it.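

Compound 3 is held only by a limit of the assay in this assay, > 50000 nM. Methyl in place of hydrogen on a saturated chain carbon bound to a double-bonded chain carbon gives an at least 1.8-fold lower number from compound 3 to compound 4 (0.26 log units; that floor lies within the scatter), so the change can be set beside its earlier counterpart on the other core, but no difference or agreement between the two can be claimed: the same change on two cores in this assay, a 1.2-fold higher number (0.09 log units; within the scatter) from compound 1 to compound 2 and an at least 1.8-fold lower number (0.26 log units; that floor lies within the scatter) from compound 3 to compound 4; the limit leaves it open whether they differ The 4-methoxyphenyl in place of 3-methoxyphenyl on a nitrogen on an aromatic ring gives no change at the digits printed from compound 1 to compound 4 (within the scatter), which holds for this one pair with the but-1-en-1-yl chain and makes no rule for the series.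

The compounds shown leave open how a longer chain than but-1-en-1-yl would read alongside the 4-methoxyphenyl group, the combination that would match compound 2. They also leave open how the series would read with an amine or a carboxylic acid at the end of the chain.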